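Terminal chain modification of a quinone-derived series

The source may hold more compounds than are shown below. What is called first, only, known or untested is meant among the compounds shown, and "the series" means these compounds.

Compound 1 `COC1=CC(=O)C(C/C=C(\C)CC/C=C(\C)CCC=C(C)C)=C(C)C1=O` returns only a limit in a functional assay on A549 cells (Homo sapiens) for inhibition, read by sulforhodamine B assay, with a stated time of 48 h (on this read-out higher numbers stand for weaker inhibition of growth and lower numbers for stronger inhibition of growth), namely > 30000 nM (the limit of > 30000 nM in this assay, at which 1 of the 3 values shown sits). Compound 2 `COC1=C(OC)[C@H](O)[C@H](C/C=C(\C)CC/C=C(\C)C[C@H](O)/C=C(\C)CO)[C@@H](C)C1=O` gives 12000 nM in this assay. Compound 3 `COC1=C(OC)[C@H](OC(C)=O)[C@H](C/C=C(\C)CC/C=C(\C)C[C@H](O)/C=C(\C)CO)[C@@H](C)C1=O` gives 29000 nM in this assay, the highest of the two numbers, with compound 2 nearest to it. Within the data shown here, the one measured step, a 2.4-fold higher number from compound 2 to compound 3 (0.38 log units; beyond the scatter), concerns the acetyl in place of hydrogen on an oxygen on a saturated carbon and is modest.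

Compound 4 `COC1=C(OC)[C@H](OC(C)=O)[C@H](C/C=C(\C)CC/C=C(\C)C[C@H](O)C[C@@H](C)C(O)O)[C@@H](C)C1=O` differs from compound 3 by a group of 6 heavy atoms (4 carbon, 2 oxygen; no ring) in place of a group of 5 heavy atoms (4 carbon, 1 oxygen; no ring), on a saturated chain carbon bound to an oxygen on a saturated carbon and a saturated chain carbon. Among the measured compounds shown here, no measured step touches the end of the chain, so the measured evidence bears on this change only in showing that the series sits at weak inhibition throughout. The expected step is a 1.0-fold higher number from compound 3 to compound 4 (0.01 log units; within the scatter), with no movement beyond the scatter foreseen in either direction. Compound 4 is therefore estimated at 30000 nM in this assay, within a range from 10000 nM to 90000 nM, with a fair chance that only a limit is reported.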

Compound 4, concentration for 50% growth inhibition: 15400 nM
Compound 4: the middle estimate sits 1.9-fold (0.29 log units) above what was measured; low and high end bracket the measured number.
By their numbers in this assay, from the lowest: compounds 2, 4 and 3 (each within the scatter of the next, the first and the last beyond it). At a limit, above all of these: compound 1.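

Among these compounds, replacing the terminal 2-(hydroxymethyl)prop-1-en-1-yl on this saturated chain carbon with the larger group, which has no double bond and adds a defined stereocentre, is the first change measured at the chain end, and it stays within the scatter (a 1.9-fold lower number from compound 3 to compound 4 (0.27 log units; within the scatter)). The larger group carries more hydrogen-bond donors and acceptors, yet at this position this assay registers no change beyond the scatter, unlike the acetyl step elsewhere on the molecule (a 2.4-fold higher number from compound 2 to compound 3 (0.38 log units; beyond the scatter)). The only limit in the set remains that of compound 1: the limit of > 30000 nM in this assay, at which 1 of the 4 values shown sits.

On these data alone, whether a carboxylic acid, an amine or a longer chain at this position would move the number beyond the scatter stays open. Also open, as far as these compounds go, is whether the acetyl step holds with the new terminal group in place.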